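Halogen exchange at the aromatic position of the iminopiperidine series

The source may report more compounds than this note shows. Statements on the series, on what has been measured and on what is new or still open speak of the compounds shown alone.

Measured compounds: compound 1 `OCc1cccc(C2=NCCCC2)c1` gives 80 nM in an assay on HEK293 cells for displacement of a labelled ligand from Neuronal acetylcholine receptor; alpha3/beta4 (Homo sapiens), read by radioligand binding, with a stated time of 5 min; on this read-out higher numbers stand for weaker inhibition and lower numbers for stronger inhibition; compound 2 `Oc1cccc(C2=NCCCC2)c1` gives 680 nM; compound 3 `Ic1cccc(C2=NCCCC2)c1` gives 4.7 nM.

Compound 3 holds the lowest number of the three, with steps to the others a 17-fold lower number from compound 1 to compound 3 (1.23 log units; beyond the scatter) and a 140-fold lower number from compound 2 to compound 3 (2.16 log units; beyond the scatter), both beyond the scatter. Compound 4 `Clc1cccc(C2=NCCCC2)c1` differs from compound 3 by chloro in place of iodo on an aromatic carbon. Going by the values given here, no measured step exchanges one halogen for another; the two steps into compound 3 only show that iodo sits far from hydroxymethyl and hydroxy. Some loss is expected from compound 3 to compound 4, estimated as a 3.2-fold higher number from compound 3 to compound 4 (0.50 log units; beyond the scatter), but smaller than those steps. Compound 4 is expected at 15 nM, within 4 nM to 60 nM.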

Compound 4, inhibition constant: 77.2 nM
Compound 4: the middle estimate sits 5.1-fold (0.71 log units) below what was measured, and the stated range ends below it.
By their numbers in this assay, from the lowest: compound 3; then compounds 4 and 1 (each within the scatter of the next); then compound 2.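

At this position on an aromatic carbon, the identity of the halogen carries weight: chloro in place of iodo gives a 16-fold higher number from compound 3 to compound 4 (1.22 log units; beyond the scatter) and takes the number away from that of compound 3. Chloro in place of hydroxymethyl gives a 1.0-fold lower number from compound 1 to compound 4 (0.02 log units; within the scatter) and so does not separate the two groups, whereas chloro in place of hydroxy still gives an 8.8-fold lower number from compound 2 to compound 4 (0.94 log units; beyond the scatter) as a clear step.

Nothing available explains why iodo and chloro differ so widely. From the compounds shown here alone, whether bromo or fluoro would follow the same trend stays open, as does the effect of an amine or a carboxylic acid here.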